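A Methyl Ester Step Repeated on a Second Core

This account rests on a few compounds, and the source may have more. Where it says the series, first, only, none or still open, it means among the compounds named here.

Compound 1 `O=C(/C=C/c1ccc(O)c(O)c1)OC[C@H]1O[C@@]2(C(=O)O)C[C@@H](OC(=O)/C=C/c3ccc(O)c(O)c3)[C@@H](O)[C@@H]1O2` and compound 2 `O=C(/C=C/c1ccc(O)c(O)c1)OC[C@H]1O[C@@]2(C(=O)O)C[C@@H](OC(=O)/C=C/c3ccc(O)c(O)c3)[C@@H](OC(=O)/C=C/c3ccc(O)c(O)c3)[C@H]1O2` share much of their structure, but the difference between the two cores is not broken down here. In a functional assay on HepG2 cells (Homo sapiens) for inhibition, read by spectrophotometry, with stated times of 5 min and 1 h (on this read-out lower numbers stand for stronger inhibition and higher numbers for weaker inhibition), compound 1 gives 79000 nM, and compound 2 gives 59500 nM, two values that lie within the usual scatter of each other. Compound 3 `COC(=O)[C@]12C[C@@H](OC(=O)/C=C/c3ccc(O)c(O)c3)[C@@H](O)[C@H](O1)[C@@H](COC(=O)/C=C/c1ccc(O)c(O)c1)O2` is made from compound 1 by one change: methyl in place of hydrogen on an oxygen next to a carbonyl group. In this assay compound 3 gives 34500 nM, a step of a 2.3-fold lower number from compound 1 to compound 3 (0.36 log units; beyond the scatter). Compound 4 `COC(=O)[C@]12C[C@@H](OC(=O)/C=C/c3ccc(O)c(O)c3)[C@@H](OC(=O)/C=C/c3ccc(O)c(O)c3)[C@@H](O1)[C@@H](COC(=O)/C=C/c1ccc(O)c(O)c1)O2` carries the same change made on compound 2: methyl in place of hydrogen on an oxygen next to a carbonyl group. Within the data shown here, because the one measured example of this change gave a 2.3-fold lower number from compound 1 to compound 3 (0.36 log units; beyond the scatter), compound 4 is expected to show a step of about a 2.2-fold lower number from compound 2 to compound 4 (0.34 log units; beyond the scatter) in this assay. On that basis compound 4 is estimated at 27000 nM, with a likely range from 13000 nM to 55000 nM.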

Compound 4, half-maximal inhibitory concentration: 26000 nM
The estimate for compound 4 lay 1.0-fold (0.02 log units) above the measured number; the range from low to high includes it.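

Replacing the hydrogen of the carboxy group with methyl, which turns carboxy into methoxycarbonyl, gives a 2.3-fold lower number from compound 2 to compound 4 (0.36 log units; beyond the scatter) in this assay. Set beside the earlier example, the change keeps its size when carried from one core to the other: the same change on two cores in this assay, a 2.3-fold lower number (0.36 log units; beyond the scatter) from compound 1 to compound 3 and a 2.3-fold lower number (0.36 log units; beyond the scatter) from compound 2 to compound 4, 1.0-fold (0.00 log units) apart, within the scatter of two such steps. Among these compounds, with only two matched pairs and a single read-out, this shows that the step repeated on these two cores, but not that it would repeat on further cores, and it does not explain why the number falls.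

The compounds shown leave open whether a longer chain in place of methyl, such as ethyl, would give a similar step. They also leave open what an amide in place of the ester would do.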